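From phenyl to 4-(dimethylamino)phenyl: estimating compound 4

The source may hold more compounds than are shown below. What is called first, only, known or untested is meant among the compounds shown, and "the series" means these compounds.

Compound 1 `COc1cc(-c2ccnc3cc(-c4c[nH]c5ccccc45)nn23)cc(OC)c1OC` gives 29 nM as its value
Compound 2 `COc1cc(-c2ccnc3cc(-c4ccc(Cl)cc4)nn23)cc(OC)c1OC` gives 3070 nM as its value
Compound 3 `COc1cc(-c2ccnc3cc(-c4ccccc4)nn23)cc(OC)c1OC` gives 208 nM as its value

All three values come from a functional assay on A549 cells (Homo sapiens) for inhibition, read by CCK-8 assay, with a stated time of 48 h (a lower number here means a stronger inhibitor, a higher number a weaker inhibitor), and the compounds share one core. Compound 3 holds the middle place among the three numbers. Compound 4 `COc1cc(-c2ccnc3cc(-c4ccc(N(C)C)cc4)nn23)cc(OC)c1OC` has not been measured yet. It differs from compound 3 in one place, with dimethylamino in place of hydrogen on an aromatic carbon, and that carbon is para to a large group.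

The closest guide is a 15-fold lower number from compound 2 to compound 3 (1.17 log units; beyond the scatter) where hydrogen replaces chloro on the matching carbon. Read in reverse, this means that the one group measured on that carbon went with a much weaker inhibitor. Two further steps, a 7.2-fold higher number from compound 1 to compound 3 (0.86 log units; beyond the scatter) and a 110-fold higher number from compound 1 to compound 2 (2.02 log units; beyond the scatter) when the indole group is exchanged, show that changes in this part of the molecule can move the number widely. Chloro and dimethylamino are different groups, and a single precedent cannot show whether the trend carries over. A higher number is therefore expected, though a smaller rise than in the chloro case. The estimated step is a 2.4-fold higher number from compound 3 to compound 4 (0.38 log units; beyond the scatter) in this assay and it remains uncertain. The estimated value for compound 4 is 500 nM with an expected range of 90 nM to 2800 nM in repeated measurements.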

Compound 4, half-maximal inhibitory concentration: 1100 nM
Beside the measured number, compound 4's estimate is 2.2-fold (0.34 log units) below it; low and high end bracket the measured number.
By their numbers in this assay, from the lowest: compound 1; then compound 3; then compound 4; then compound 2.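

In this assay, dimethylamino on this aromatic carbon, para to a large group, also goes with a weaker inhibitor, with a 5.3-fold higher number from compound 3 to compound 4 (0.72 log units; beyond the scatter) in this series, so compound 3, with hydrogen there, now gives a lower number than both compounds that carry a group at this carbon. The two groups do not cost the same, since there is a 2.8-fold lower number from compound 2 to compound 4 (0.45 log units; beyond the scatter) on exchanging chloro for dimethylamino, which shows that the size of the rise depends on which group enters and not merely on the carbon being occupied. Compound 4 also stays far from the indole compound, with a 38-fold higher number from compound 1 to compound 4 (1.58 log units; beyond the scatter) on the return from compound 1 read the other way, and nothing among the data shown gives a measured reason for any of these steps.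

The compounds shown leave open whether a methyl, a methoxy or a plain amino group on this same carbon would follow chloro and dimethylamino toward a higher number or stay close to compound 3. They also leave open how chloro or dimethylamino would behave on the other carbons of this phenyl ring, and whether any such group could bring the phenyl series nearer to compound 1.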